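The source may report more compounds than this note shows. Statements on the series, on what has been measured and on what is new or still open speak of the compounds shown alone.

Values in a functional assay on MGC-803 cells (Homo sapiens) for antiproliferative activity, read by MTT assay, with a stated time of 48 h (a higher number here means a weaker inhibitor, a lower number a stronger inhibitor), for the three measured members of the series:
compound 1, `O=C(Nc1cccc(CNc2nccnc2Cl)c1)Nc1ccccc1F`: 6440 nM
compound 2, `O=C(Nc1cccc(CNc2nccnc2Cl)c1)NC1CCCCC1`: > 40000 nM, a limit of the assay, not a number
compound 3, `Cc1ccc(NC(=O)Nc2cccc(CNc3nccnc3Cl)c2)c(C)c1`: 10100 nM

Compound 3 stands beside compound 1; the two values sit within the scatter of each other, a 1.6-fold higher number from compound 1 to compound 3 (0.20 log units; within the scatter). For compound 2 this assay reports only a limit, (the limit of > 40000 nM in this assay, at which 1 of the 3 values shown sits). Relative to that limit compound 3 shows an at least 3.9-fold lower number from compound 2 to compound 3 (0.59 log units; beyond the scatter), and compound 1 shows an at least 6.2-fold higher number from compound 1 to compound 2 (0.79 log units; beyond the scatter), so the only steps beyond the scatter are those exchanging an aryl group for cyclohexyl on the amide-type nitrogen.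

Compound 4, `Cc1ccccc1NC(=O)Nc1cccc(CNc2nccnc2Cl)c1`, differs from compound 3 by hydrogen in place of methyl on an aromatic carbon. The step that bears most directly on it is the aryl-to-aryl exchange, a 1.6-fold higher number from compound 1 to compound 3 (0.20 log units; within the scatter), which stayed within the scatter. The two steps involving cyclohexyl are beyond the scatter but concern a change of a different kind, the loss of the aromatic ring itself, which compound 4 keeps. A single methyl removed from the retained aryl group is therefore expected to give a step of at most the size seen from compound 1 to compound 3: a 1.2-fold lower number from compound 3 to compound 4 (0.07 log units; within the scatter) is the expected step, in either direction and not beyond the scatter. Compound 4 is accordingly estimated at 8500 nM in this assay, with a range from 4000 nM to 20000 nM.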

Compound 4, half-maximal inhibitory concentration: 14000 nM
Beside the measured number, compound 4's estimate is 1.6-fold (0.22 log units) below it; the measured number falls inside the stated range.
By their numbers in this assay, from the lowest: compounds 1, 3 and 4 (each within the scatter of the next, the first and the last beyond it). At a limit, above all of these: compound 2.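

In this assay, hydrogen and methyl on the aromatic carbon para to a large group give values within the scatter of each other, a 1.4-fold higher number from compound 3 to compound 4 (0.14 log units; within the scatter), so in this pair the 2,4-dimethylphenyl to 2-methylphenyl change does not register. Among these compounds, the exchange of fluoro for methyl on an aromatic carbon is the first step between two aryl groups to pass the scatter, if only modestly, a 2.2-fold higher number from compound 1 to compound 4 (0.34 log units; beyond the scatter), while compound 3, which also carries that methyl, goes against any general reading of this step: a 1.6-fold higher number from compound 1 to compound 3 (0.20 log units; within the scatter). Compound 2 stands at a limit, not a number, and 2-methylphenyl in place of cyclohexyl gives an at least 2.8-fold lower number from compound 2 to compound 4 (0.45 log units; beyond the scatter), so a third aryl group separates from cyclohexyl beyond the scatter: the limit of > 40000 nM in this assay, at which 1 of the 4 values shown sits.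

Still open, as far as these compounds go, is whether a methoxy, an amine or a carboxylic acid on the same aromatic carbon would stay within the scatter of hydrogen and methyl, since only those two substituents are compared there. An unsubstituted phenyl would show how much of the step from 2-fluorophenyl to 2-methylphenyl belongs to the fluoro and how much to the methyl.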